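The source may report more compounds than this note shows. Statements on the series, on what has been measured and on what is new or still open speak of the compounds shown alone.

Measured so far in a functional assay on the whole organism (strain Sprague-Dawley) for inhibition, with Rattus norvegicus as the target; a lower number here means that less compound is needed, a higher number that more compound is needed for the effect:
Compound 1 `COc1ccc2ncc(C(=O)O)cc2c1` gives > 5 mg/kg, a limit of the assay and not a number.
Compound 2 `O=C(O)c1cnc2cc(C(F)(F)F)ccc2c1` gives > 25 mg/kg, also a limit of the assay.
Compound 3 `O=C(O)c1cnc2ccc(C(F)(F)F)cc2c1` gives > 25 mg/kg, again a limit of the assay.

Compound 1 and compound 3 differ in one place, (methoxy in place of trifluoromethyl on an aromatic carbon). The resulting step is a step that the two limits leave unreadable from compound 3 to compound 1, since both ends are limits. Two of the three values sit at the limit of > 25 mg/kg in this assay, at which 2 of the 3 values shown sit, the remaining one at the limit of > 5 mg/kg in this assay, at which 1 of the 3 values shown sits. Compound 2 and compound 3 are built from the same atoms joined differently; the difference between the two cores is not broken down here.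

Compound 4 `COc1ccc2cc(C(=O)O)cnc2c1` has not yet been measured in this assay. It stands to compound 2 as compound 1 stands to compound 3: methoxy in place of trifluoromethyl on an aromatic carbon, the same change at a place described in the same words. For the measured compounds named here, the expected step is a number no higher from compound 2 to compound 4 (the limit leaves the size open), which rests on nothing more than the unreadable earlier step and on the fact that the series so far sits at limits, chiefly because two of the three values are at the limit of > 25 mg/kg in this assay, at which 2 of the 3 values shown sit. Compound 4 is accordingly estimated at 25 mg/kg, somewhere between 5 mg/kg and 100 mg/kg, most probably reported once more as a limit.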

Compound 4, minimum effective dose: > 25 mg/kg
Compound 4 ended at the assay's limit; the forecaster's own chance of this, stated with the estimate: 80%; the middle value lies on the limit itself.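

In this assay compound 2 and compound 4 each stand at a limit of the assay, so no step can be read between them, just as none can between compound 3 and compound 1. The compounds shown leave open what minimum effective dose any of the four has, and whether methoxy in place of trifluoromethyl changes it at all.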